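Methoxy for Methyl on the Aniline Ring of an Acid

The compounds below may be only part of what the source reports. "The series", "measured", "known", "first", "only" and "open" are said of these compounds alone.

Measured compounds:
Compound 1, `COC(=O)c1c(Nc2ccccc2)sc(C(=O)c2ccc(OC)cc2)c1C`: 28.6%
Compound 2, `COC(=O)c1c(Nc2ccccc2)sc(C(=O)c2ccc(C)cc2)c1C`: 4.59%
Compound 3, `COc1ccc(C(=O)c2sc(Nc3ccc(C)cc3)c(C(=O)O)c2C)cc1`: "not active" (no number reported)

The three measured compounds were tested in a functional assay, with a stated time of 150 min, tested at 15 ug/mL; on this read-out lower numbers stand for a weaker effect and higher numbers for a stronger effect at the one concentration tested. Compound 2 gives 4.59%, and compound 1 gives 28.6% in this assay. The difference between them is methoxy in place of methyl on an aromatic carbon, and the step is a number 24 percentage points higher from compound 2 to compound 1 (beyond the scatter). Compound 3 was reported as "not active" (no number reported) in this assay, so no number stands for it. The difference between the cores of compound 2 and compound 3 is not broken down here.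

Compound 4, `COc1ccc(Nc2sc(C(=O)c3ccc(OC)cc3)c(C)c2C(=O)O)cc1`, has not been measured. It differs from compound 3 by methoxy in place of methyl on an aromatic carbon, the same change as that from compound 2 to compound 1, occurring twice among these compounds. For the measured compounds named here, since compound 3 gave no number, the step cannot be gauged directly; the expectation rests on the one earlier step, which was modest and on a weakly active starting point. On that basis, compound 4 is expected to give about 12% in this assay, with a range from 0% to 35%.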

Compound 4, a percentage reported as activity, at one concentration (the size of the read-out at that concentration, not a potency): 30.6%
Compound 4: the middle estimate sits 18.6 percentage points below what was measured; low and high end bracket the measured number.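

In this assay, for the compounds shown here, compound 4 gives 30.6% while compound 3 has no number, so no step between compound 3 and compound 4 can be read. No measurement shown offers an explanation for this result. The compounds shown leave open how large a change (4-methylphenyl)amino to (4-methoxyphenyl)amino brings on the core of compound 3.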